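A few compounds are considered here, and "the series" means these few. Any claim that something is new, unique, unknown or untested is made for them only; others in the source may bear on it.

Of the compounds shown here, three share one core and have been tested in an assay on isolated protein for displacement of a labelled ligand from metabotropic glutamate receptor 5 (Homo sapiens), with a stated time of 60 min, tested at 1 uM; on this read-out lower numbers stand for less inhibition and higher numbers for more inhibition at the one concentration tested (going by the name of the read-out). Compound 1 `CC1CCN(c2c(S(=O)(=O)c3ccc(F)cc3)cnc3ccc(F)cc23)CC1` gives 87%. Compound 2 `COc1cccc(S(=O)(=O)c2cnc3ccc(Cl)cc3c2N2CCC(C)CC2)c1` gives 87%. Compound 3 `COc1ccc(S(=O)(=O)c2cnc3ccc(F)cc3c2N2CCC(C)CC2)cc1` gives 85%, which sits level with the other two, as the gap to compound 1 and the gap to compound 2 each lie within the scatter. Going by the values given here, the only single-point step recorded, a number 2 percentage points lower from compound 1 to compound 3 (within the scatter), shows that putting methoxy in place of fluoro on an aromatic carbon leaves the read-out essentially where it was.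

Compound 4 `COc1cccc(S(=O)(=O)c2cnc3ccc(F)cc3c2N2CCC(C)CC2)c1` differs from compound 3 in one place: 3-methoxyphenyl in place of 4-methoxyphenyl on a sulfonyl sulfur. Among the compounds with values here, no recorded step compares a 4-methoxyphenyl with a 3-methoxyphenyl, so there is no direct precedent. Compound 2 also carries a 3-methoxyphenyl on the sulfonyl sulfur, and in this assay compound 2 gives 87%, a number in the same band as the others. Since the one step shown lies within the scatter, the step from compound 3 to compound 4 is expected to be a number 1 percentage points higher from compound 3 to compound 4 (within the scatter), meaning no change beyond the scatter. Compound 4 is therefore estimated at 86%, with a range from 78% to 93%.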

Compound 4, a percentage reported as inhibition, at one concentration (the size of the read-out at that concentration, not a potency): 90%
Beside the measured number, compound 4's estimate is 4 percentage points below it; measured number inside the range.
By their numbers in this assay, from the lowest: compounds 3, 1, 2 and 4 (each within the scatter of the next).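

In this assay, going by these compounds alone, 3-methoxyphenyl in place of 4-methoxyphenyl on a sulfonyl sulfur gives a number 5 percentage points higher from compound 3 to compound 4 (within the scatter), the first direct comparison of these two groups, while 3-methoxyphenyl in place of 4-fluorophenyl at the same place gives a number 3 percentage points higher from compound 1 to compound 4 (within the scatter). Fluoro in place of chloro on an aromatic carbon, with 3-methoxyphenyl on the sulfonyl sulfur in both compounds, gives a number 3 percentage points higher from compound 2 to compound 4 (within the scatter), so none of these three changes moves the read-out beyond the scatter. No measurement available here offers an explanation for these small differences.

With all four numbers this close at a single concentration, the compounds cannot be ranked. From the compounds shown here alone, it remains open whether an amine or a carboxylic acid in place of the methoxy group would keep the read-out in this band.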